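This account rests on a few compounds, and the source may have more. Where it says the series, first, only, none or still open, it means among the compounds named here.

In a functional assay on HCT-116 cells (Homo sapiens) for inhibition, read by MTT assay, with a stated time of 2 days, tested at 10 uM (on this read-out higher numbers stand for more inhibition at the one concentration tested (going by the name of the read-out) and lower numbers for less inhibition), compound 1 `COc1ccc(OC)c(-c2cn(-c3ccc(O)c(C(=O)Nc4cccc(C(F)(F)F)c4)c3)nn2)c1` gives 46%. Compound 2 `COc1ccccc1-c1cn(-c2ccc(O)c(C(=O)Nc3cccc(C(F)(F)F)c3)c2)nn1` gives 61%. The change a number 15 percentage points higher from compound 1 to compound 2 (beyond the scatter) leaves compound 2 with the higher of the two numbers. Compound 3 `COC(=O)c1cc(-n2cc(-c3ccccc3OC)nn2)ccc1O` differs from compound 2 by methoxy in place of (3-(trifluoromethyl)phenyl)amino on a carbonyl carbon. Among the compounds with values here, no measured step touches the carbonyl carbon; the single known step is a change on an aromatic carbon and does not bear on this larger swap. A drop in this assay is nevertheless expected for compound 3, estimated as a number 26 percentage points lower from compound 2 to compound 3 (beyond the scatter). Compound 3 is therefore expected to reach 35%, within 10% to 60%.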

Compound 3, a percentage reported as inhibition, at one concentration (the size of the read-out at that concentration, not a potency): 8%
Compound 3: middle estimate off by 27 percentage points, on the high side, outside the stated range (below it).
By their numbers in this assay, from the lowest: compound 3; then compound 1; then compound 2.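

In this assay, putting methoxy in place of (3-(trifluoromethyl)phenyl)amino on the carbonyl carbon gives a number 53 percentage points lower from compound 2 to compound 3 (beyond the scatter), a large step and the first measured at this position. The group on this carbonyl carbon therefore matters strongly for this read-out, and methoxy does not stand in for the larger group. Nothing available explains the drop.

As far as these compounds go, this single swap removes the aromatic ring, the trifluoromethyl and the amide hydrogen together, so their separate shares stay open. Plain phenylamino or a carboxylic acid on the same carbon would help to separate them.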